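The compounds below may be only part of what the source reports. "The series", "measured", "known", "first", "only" and "open" are said of these compounds alone.

Compound 2 `COc1ccc2sc(NC(=O)c3ccc(C#N)cc3)nc2c1` carries a cyano group on the aromatic ring of its amide, and in a functional assay on NUGC-3 cells (Homo sapiens) for antiproliferative activity, read by sulforhodamine B assay (a lower number here means a stronger inhibitor of growth, a higher number a weaker inhibitor of growth), compound 2 gives only the limit of > 10 ug/mL, which is a boundary of the assay rather than a measured number. Compound 1 `COc1ccc2sc(NC(=O)c3ccc(C(F)(F)F)cc3)nc2c1`, which has a trifluoromethyl group in the same place, also stops at the limit of > 10 ug/mL in this assay. A third compound, compound 3 `COc1ccccc1NC(=O)Nc1nc2ccc(F)cc2s1`, built around a urea instead of an amide, likewise reports only the limit of > 10 ug/mL. Going by the values given here, the single comparison between measured compounds, a step that the two limits leave unreadable from compound 1 to compound 2, cannot be read because of the limit of > 10 ug/mL in this assay, at which 3 of the 3 values shown sit.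

Compound 4 `COc1ccc2sc(NC(=O)c3ccc(C)cc3)nc2c1` differs from compound 2 in one place: methyl in place of cyano on an aromatic carbon. Among the compounds with values here, no measured step shows what swapping a cyano for a methyl on an aromatic carbon does, so there is nothing to suggest a move beyond the usual scatter in either direction. Within the data shown here, with no measured step to lean on, the expected change is estimated as a step that the limit leaves unreadable from compound 2 to compound 4. Compound 4 is therefore expected to stop at the limit once more, with an estimated value of 15 ug/mL and a range from 5 ug/mL to 50 ug/mL.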

Compound 4, concentration for 50% growth inhibition: > 10 ug/mL
Compound 4 was reported as a limit (the forecaster's own chance of this, stated with the estimate: 80%); the middle value does not contradict the limit.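

The steps from compound 1 and from compound 2 to compound 4 cannot be read, because each compared pair gives two limits rather than numbers: the limit of > 10 ug/mL in this assay, at which 4 of the 4 values shown sit.

The compounds shown leave open whether trifluoromethyl, cyano and methyl differ in their effect on growth in this assay, and how far any of these compounds lies past the limit.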